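The source may report more compounds than this note shows. Statements on the series, on what has been measured and on what is new or still open speak of the compounds shown alone.

Going by the values given here, in a functional assay on a cell-free system (Platelet, plasma, Homo sapiens) for inhibition, read by turbidimetry, with a stated time of 3 min (on this read-out lower numbers stand for stronger inhibition and higher numbers for weaker inhibition), compound 1 `COc1ccc(-n2nc(C(=O)N3CCCCC3)cc2-c2ccc(Cl)cc2)nn1` gives 41 nM, the lowest of the three numbers measured so far. Compound 2 `COc1ccc(NC(=O)c2cc(-c3ccc(Cl)cc3)n(-c3ccc(OC)nn3)n2)cc1` gives 400 nM, and compound 3 `COc1ccc(-n2nc(C(=O)Nc3ccc(Cl)cc3)cc2-c2ccc(Cl)cc2)nn1` gives 610 nM. Compound 4 `CS(=O)(=O)c1ccc(-n2nc(C(=O)N3CCCCC3)cc2-c2ccc(Cl)cc2)nn1` has not yet been measured. It keeps the piperidin-1-yl on the carbonyl carbon and differs from compound 1 by methylsulfonyl in place of methoxy on an aromatic carbon, which turns 6-methoxypyridazin-3-yl into 6-(methylsulfonyl)pyridazin-3-yl.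

Among the compounds with values here, none of the measured steps makes this change. The steps of a 9.8-fold higher number from compound 1 to compound 2 (0.99 log units; beyond the scatter) and a 15-fold higher number from compound 1 to compound 3 (1.17 log units; beyond the scatter) alter the group on the carbonyl carbon, so they bear on it only by showing how far numbers in this small set can move. The step of a 1.5-fold higher number from compound 2 to compound 3 (0.18 log units; within the scatter) replaces a methoxy elsewhere in the molecule, with chloro rather than methylsulfonyl entering. Within the data shown here, the direction therefore remains poorly supported, but with compound 1 at 41 nM, the lowest number so far, a modest rise is expected. The expected change is a 3.7-fold higher number from compound 1 to compound 4 (0.56 log units; beyond the scatter). Compound 4 is estimated at 150 nM, with an expected range of 30 nM to 800 nM.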

Compound 4, half-maximal inhibitory concentration: 19600 nM
Beside the measured number, compound 4's estimate is 130-fold (2.12 log units) below it, and the stated range ends below it.
By their numbers in this assay, from the lowest: compound 1; then compounds 2 and 3 (each within the scatter of the next); then compound 4.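

In this assay, this position on the six-membered aromatic ring with 2 nitrogen proves highly sensitive: with the piperidin-1-yl on the carbonyl carbon kept, methylsulfonyl in place of methoxy gives a 480-fold higher number from compound 1 to compound 4 (2.68 log units; beyond the scatter). The earlier compounds had shown change only at the carbonyl carbon and at a methoxy elsewhere in the molecule, and this single replacement moves the number further than any of those steps. The data offer no measured explanation for the loss.

Only one replacement for methoxy is shown here, so it remains open whether the rise is specific to methylsulfonyl or follows from removing methoxy itself. Methylthio, ethoxy or dimethylamino at this position would help separate those readings, and the same exchange alongside (4-chlorophenyl)amino on the carbonyl carbon would test whether the effect carries over.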